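The source may hold more compounds than are shown below. What is called first, only, known or untested is meant among the compounds shown, and "the series" means these compounds.

Going by the values given here, compound 2 `O=C(O)c1ccc(CN2C(=O)S/C(=C\c3cccs3)C2=O)cc1` gives 76000 nM in a functional assay on HeLa cells (Homo sapiens) for cytotoxicity, read by MTT assay, with a stated time of 24 h (a higher number here means a weaker inhibitor, a lower number a stronger inhibitor), the highest of the two numbers measured so far, yet it sits within the scatter of compound 1 `O=C(O)c1ccc(CN2C(=O)S/C(=C\c3ccccc3)C2=O)cc1`, which gives 72000 nM. Among the compounds with values here, the single measured step, a 1.1-fold higher number from compound 1 to compound 2 (0.02 log units; within the scatter), therefore shows no real movement. Compound 3 `O=C(O)c1ccc(CN2C(=O)S/C(=C\c3ccc(Br)cc3)C2=O)cc1` differs from compound 2 by 4-bromophenyl in place of thiophen-2-yl on a double-bonded chain carbon bound to a double-bonded ring carbon. Within the data shown here, only that one step bears on this change, and because it was a 1.1-fold higher number from compound 1 to compound 2 (0.02 log units; within the scatter), nothing beyond the scatter is expected here either. Compound 3 is estimated to give 70000 nM, between 30000 nM and 160000 nM. The expected step is a 1.1-fold lower number from compound 2 to compound 3 (0.04 log units; within the scatter).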

Compound 3, half-maximal inhibitory concentration: 38000 nM
Compound 3: middle estimate off by 1.8-fold (0.27 log units), on the high side; measured number inside the range.
By their numbers in this assay, from the lowest: compounds 3, 1 and 2 (each within the scatter of the next).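

In this assay, 4-bromophenyl in place of thiophen-2-yl gives a 2.0-fold lower number from compound 2 to compound 3 (0.30 log units; within the scatter) and bromo in place of hydrogen on an aromatic carbon gives a 1.9-fold lower number from compound 1 to compound 3 (0.28 log units; within the scatter) as its step. So this position on the double-bonded chain carbon now holds three different aromatic groups, including one with a bromine, and no step among them goes beyond the scatter. Nothing available explains these numbers. Still open, from the compounds shown here alone, is whether a group of another kind here, such as an amine or a carboxylic acid on the aromatic ring in place of bromo, would move the number beyond the scatter.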